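The source may report more compounds than this note shows. Statements on the series, on what has been measured and on what is new or still open speak of the compounds shown alone.

Three compounds of this series have been examined in a functional assay on the whole organism (strain Swiss albino) with Mus musculus as the target, in the maximal electroshock model, with a stated time of 0.5 h; a lower number here means that less compound is needed, a higher number that more compound is needed for the effect. Compound 1 `C/C(=N/NC(=O)Nc1nnc(COc2ccc3ccccc3c2)o1)c1ccc(O)cc1` gives 100 mg/kg. Compound 3 `O=C(N/N=C(/c1ccccc1)c1ccc([N+](=O)[O-])cc1)Nc1nnc(COc2ccc3ccccc3c2)o1` gives 100 mg/kg, level with compound 1 at the digits reported, and together these two hold the lowest number of the three. Compound 2 `O=C(N/N=C\c1ccc([N+](=O)[O-])cc1)Nc1nnc(COc2ccc3ccccc3c2)o1` gives 300 mg/kg, a number that stands beyond the usual scatter from compound 1. Among the measured compounds shown here, no step between measured compounds that differ in a single place is available, so what the nitro brings can only be read from these values as a whole. Compound 4 `C/C(=N/NC(=O)Nc1nnc(COc2ccc3ccccc3c2)o1)c1ccc([N+](=O)[O-])cc1` differs from compound 1 in one place: nitro in place of hydroxy on an aromatic carbon. Cut one bond further out, the same difference reads 4-hydroxyphenyl to 4-nitrophenyl. Compound 3 also carries the nitrophenyl and sits at the low end, while compound 2, likewise with the nitrophenyl, sits higher; the expectation is therefore a small step, upward if anything, probably within the scatter. Compound 4 is estimated at 150 mg/kg, within 70 mg/kg to 300 mg/kg. The step that this estimate implies is expected to be a 1.5-fold higher number from compound 1 to compound 4 (0.18 log units; within the scatter).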

Compound 4, minimum effective dose: 100 mg/kg
Compound 4: the middle estimate sits 1.5-fold (0.18 log units) above what was measured; the range from low to high includes it.
By their numbers in this assay, from the lowest: compounds 1, 3 and 4 (each within the scatter of the next); then compound 2.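

Among the compounds shown here, the first direct reading at this position, nitro in place of hydroxy on an aromatic carbon para to a large group, shows no change at the digits printed from compound 1 to compound 4 (within the scatter) in this assay and so does not separate the two groups on this scaffold. With the 4-nitrophenyl held in place, methyl in place of phenyl on the carbon with a double bond to nitrogen shows no change at the digits printed from compound 3 to compound 4 (within the scatter) in this assay, so this second place also gives no separation between the two groups compared. Nothing measured here speaks to what lies behind either result.

As far as these compounds go, whether an amine, a methoxy group or a carboxylic acid at the same aromatic carbon would read the same remains open. So does whether a longer chain such as ethyl or propyl in place of the methyl would leave the number where it stands.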